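The source may report more compounds than this note shows. Statements on the series, on what has been measured and on what is new or still open speak of the compounds shown alone.

Of the compounds shown here, three sharing one core have been measured in an ADME assay on the whole organism with Oryza sativa as the target, tested at 0.1 uM; a lower number here means a stronger effect, a higher number a weaker effect of the compound at the concentration tested. Compound 1 `Cc1ccccc1NC(=O)N[C@H](C)c1ccccc1` gives 100% in this assay. Compound 2 `CCc1ccccc1NC(=O)N[C@H](C)c1ccccc1` adds a methyl in place of hydrogen on a saturated chain carbon bound to an aromatic carbon, and in this assay compound 2 gives 101%, so that a number 1 percentage points higher from compound 1 to compound 2 (within the scatter). Compound 3 `CCc1ccccc1NC(=O)N[C@@H](C)c1ccccc1` has the same atoms and bonds as compound 2 and differs only in the configuration drawn at the stereocentre (the fact that compounds 2 and 3 differ only in the configuration as drawn); in this assay compound 3 gives 100%, and a number 1 percentage points lower from compound 2 to compound 3 (within the scatter). Compound 2 therefore stands among three numbers that all lie within the scatter of one another, with no real difference between them.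

Compound 4 `CC(C)c1ccccc1NC(=O)N[C@H](C)c1ccccc1` has not yet been measured. It differs from compound 2 by methyl in place of hydrogen on a saturated chain carbon bound to an aromatic carbon and a saturated chain carbon. For the measured compounds named here, two measured steps bear on this change. The earlier addition of a methyl on the same saturated chain carbon gave a number 1 percentage points higher from compound 1 to compound 2 (within the scatter), and the change of configuration gave a number 1 percentage points lower from compound 2 to compound 3 (within the scatter); both stayed within the scatter. Compound 4 is therefore expected to show a step of a number 1 percentage points lower from compound 2 to compound 4 (within the scatter), again within the scatter. Compound 4 is estimated to give 100% in this assay, with a likely range from 90% to 108%.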

Compound 4, a percentage reported as activity, at one concentration (the size of the read-out at that concentration, not a potency): 103%
For compound 4 the middle estimate is 3 percentage points below the measured one, within the range that was stated.
By their numbers in this assay, from the lowest: compounds 1, 3, 2 and 4 (each within the scatter of the next).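

In this assay the change from ethyl to isopropyl, a methyl in place of hydrogen on a saturated chain carbon bound to an aromatic carbon and a saturated chain carbon, gives a number 2 percentage points higher from compound 2 to compound 4 (within the scatter) and so adds a second step of the same kind at this place to the one seen before. Read across the whole change, isopropyl in place of methyl on an aromatic carbon gives a number 3 percentage points higher from compound 1 to compound 4 (within the scatter), so even the largest group shown here leaves the read-out within the scatter of the smallest one. Nothing available here explains why these steps are so small, and no cause can be offered for them.

Since every step in this series stays within the scatter, the compounds shown cannot tell whether any group at this place can change the read-out at this concentration. From the compounds shown here alone, whether a longer chain, an amine or a carboxylic acid on the same aromatic carbon would give a real step remains open, as does whether the drawn configuration matters once isopropyl is present.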